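This account rests on a few compounds, and the source may have more. Where it says the series, first, only, none or still open, it means among the compounds named here.

Working notes on the series, read in an ADME assay on MT4 cells (Homo sapiens) for cytotoxicity, read by MTT assay, with a stated time of 96 h (a higher number here means that more compound is tolerated, a lower number that less compound is tolerated), throughout. Compound 1 `CC(=O)c1ccc2[nH]c(-c3ccc(Cl)cc3)nc2c1` is recorded as "not determined" (no result reported) and offers no number for comparison. Going by the values given here, compound 2 `CC(=O)c1ccc2c(c1)nc(-c1ccc(Cl)cc1)n2C1CCCCC1` reads 58000 nM in this assay and stands as one of only two numbers. The other is compound 3 `CC(=O)c1ccc2c(c1)nc(-c1ccc(C(F)(F)F)cc1)n2C1CCCCC1` at 41000 nM in the same assay, and the two lie within the scatter of each other.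

Compound 4 `CC(=O)c1ccc2c(c1)nc(-c1ccccn1)n2C1CCCCC1` is still unmeasured. Its change from compound 2 is pyridin-2-yl in place of 4-chlorophenyl on an aromatic carbon that is, pyridin-2-yl in place of 4-chlorophenyl on an aromatic carbon.

Among the compounds with values here, the only measured step, a 1.4-fold lower number from compound 2 to compound 3 (0.15 log units; within the scatter), puts trifluoromethyl in place of chloro and keeps the aromatic ring of carbon only. It therefore bears only loosely on a change of the whole ring. Within the data shown here, no measured compound carries pyridin-2-yl, so no direction is favoured, and no step beyond the scatter is expected in this assay for this change.

The expected step is a 1.0-fold higher number from compound 2 to compound 4 (0.01 log units; within the scatter) as an estimate only. For compound 4 the estimated value is 60000 nM with an expected range from 25000 nM to 130000 nM in this assay.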

Compound 4, half-maximal cytotoxic concentration: 70000 nM
The estimate for compound 4 lay 1.2-fold (0.07 log units) below the measured number; low and high end bracket the measured number.
By their numbers in this assay, from the lowest: compounds 3, 2 and 4 (each within the scatter of the next).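

In this assay the exchange of 4-chlorophenyl for pyridin-2-yl gives a 1.2-fold higher number from compound 2 to compound 4 (0.08 log units; within the scatter) and so stays within the scatter, as does the smaller exchange of trifluoromethyl for chloro in a 1.4-fold lower number from compound 2 to compound 3 (0.15 log units; within the scatter) at the far end of the same ring. Until now every number in the series came from an aromatic ring of carbon only on the aromatic carbon between two ring nitrogen atoms, whereas compound 4 shows that a six-membered aromatic ring with 1 hetero atom, 1 hydrogen-bond acceptor and no chlorine gives a reading that cannot be separated from that of compound 2. No measured evidence bears on why the reading holds across this change.

Going by these compounds, whether a carboxylic acid or an amine on this ring, or a saturated ring such as piperidine in its place, would give a step beyond the scatter remains open. On these data alone, the contribution of the cyclohexyl group also remains open, as the step from compound 1 to compound 2 cannot be read.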